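The source may report more compounds than this note shows. Statements on the series, on what has been measured and on what is new or still open speak of the compounds shown alone.

In an in vivo ADME assay on the whole organism (plasma) for pharmacokinetics, with Rattus norvegicus as the target, at a dose of 50 mg/kg by the oral route (on this read-out lower numbers stand for lower exposure and higher numbers for higher exposure at the dose given), compound 1 `Cc1cc(C)c(NC(=O)c2sccc2S(=O)(=O)Nc2onc(C)c2Cl)c(C)c1CO` gives 5110 nM, compound 2 `CC(=O)OCc1c(C)cc(C)c(NC(=O)c2sccc2S(=O)(=O)Nc2onc(C)c2Cl)c1C` gives 7420 nM and compound 3 `Cc1cc(C)c(NS(C)(=O)=O)c(C)c1NC(=O)c1sccc1S(=O)(=O)Nc1onc(C)c1Cl` gives 5250 nM. Compound 3 holds the second highest of these three numbers, but that rank carries little weight, since its steps to both other compounds lie within the scatter.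

Compound 4 `Cc1cc(C)c(NC(=O)c2sccc2S(=O)(=O)Nc2onc(C)c2Cl)c(C)c1O` follows from compound 3 by one change, hydroxy in place of methanesulfonamido on an aromatic carbon. Going by the values given here, no measured compound carries hydroxy there, so the data do not test this group directly.

The nearest evidence comes from two other exchanges on an aromatic carbon. Replacing hydroxymethyl with methanesulfonamido gives a 1.0-fold higher number from compound 1 to compound 3 (0.01 log units; within the scatter), and replacing acetoxymethyl with methanesulfonamido gives a 1.4-fold lower number from compound 2 to compound 3 (0.15 log units; within the scatter). Adding acetyl to the oxygen of the hydroxymethyl group gives a 1.5-fold higher number from compound 1 to compound 2 (0.16 log units; within the scatter). All three steps are within the scatter, so none of the changes seen so far has moved the number measurably. On that basis, no step beyond the scatter is expected for the new exchange, although three compounds are a thin basis for this. The expected change is a 1.2-fold lower number from compound 3 to compound 4 (0.07 log units; within the scatter). Compound 4 is estimated at 4500 nM, with an expected range from 1800 nM to 9500 nM.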

Compound 4, maximal plasma concentration: 106000 nM
Compound 4: the middle estimate sits 24-fold (1.37 log units) below what was measured; measured number above the stated range.
By their numbers in this assay, from the lowest: compounds 1, 3 and 2 (each within the scatter of the next); then compound 4.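

In this assay, hydroxymethyl, acetoxymethyl and methanesulfonamido on this aromatic carbon had stayed within the scatter of one another, so the position had looked tolerant of exchange with no visible effect on the number. Hydroxy ends that picture, giving a 20-fold higher number from compound 3 to compound 4 (1.31 log units; beyond the scatter) when it replaces methanesulfonamido, a 14-fold higher number from compound 2 to compound 4 (1.15 log units; beyond the scatter) when it replaces acetoxymethyl and a 21-fold higher number from compound 1 to compound 4 (1.32 log units; beyond the scatter) when it replaces hydroxymethyl, all three beyond the scatter. Compound 1 also carries a hydroxy group, but within hydroxymethyl, so among these four compounds the high number goes with hydroxy set directly on the aromatic carbon and not with the mere presence of a hydroxy group in the substituent.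

From the compounds shown here alone, whether an amine or a methoxy group on this carbon would also give a high number remains open, and so does whether the jump is specific to hydroxy or shared by other small groups placed there. The data shown contain no measurement that explains why this single exchange raises the number so far.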